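A few compounds are considered here, and "the series" means these few. Any claim that something is new, unique, unknown or untested is made for them only; others in the source may bear on it.

compound 1 `COc1cc([C@@H]2[C@H](Oc3ccccc3)C(=O)N2c2cc(OC)c(OC)c(OC)c2)cc(OC)c1OC` gives 29000 nM
compound 2 `COc1ccc([C@@H]2[C@H](Oc3ccccc3)C(=O)N2c2cc(OC)c(OC)c(OC)c2)cc1OC` gives 26000 nM
compound 3 `COc1cc(N2C(=O)[C@@H](Oc3ccccc3)[C@H]2c2ccc(S(C)(=O)=O)cc2)cc(OC)c1OC` gives 62000 nM

In a functional assay on MCF7 cells (Homo sapiens) for antiproliferative activity, read by MTT assay, with stated times of 24 h and 72 h (on this read-out higher numbers stand for weaker inhibition and lower numbers for stronger inhibition), compound 3 has the highest number of the three. Compound 4 `COc1cc([N+](=O)[O-])c([C@@H]2[C@H](Oc3ccccc3)C(=O)N2c2cc(OC)c(OC)c(OC)c2)cc1O` differs from it as follows: a group of 12 heavy atoms (7 carbon, 1 nitrogen, 4 oxygen; one six-membered aromatic ring of carbon only) in place of a group of 10 heavy atoms (7 carbon, 2 oxygen, 1 sulfur; one six-membered aromatic ring of carbon only), on a saturated ring carbon. Two measured steps change the group at this same carbon, a 2.1-fold higher number from compound 1 to compound 3 (0.33 log units; beyond the scatter) and a 2.4-fold higher number from compound 2 to compound 3 (0.38 log units; beyond the scatter). Both are modest and beyond the scatter, while a 1.1-fold lower number from compound 1 to compound 2 (0.05 log units; within the scatter) stays within it. Among the measured compounds shown here, no measured compound carries the entering group, so this evidence is indirect. Compound 4 is expected to resemble compound 1 and compound 2 more than compound 3, with a modest move to a lower number. The expected step is a 3.1-fold lower number from compound 3 to compound 4 (0.49 log units; beyond the scatter). For compound 4 the estimated value is 20000 nM, with an expected range from 4000 nM to 70000 nM.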

Compound 4, half-maximal inhibitory concentration: 59000 nM
The estimate for compound 4 lay 3.0-fold (0.47 log units) below the measured number; low and high end bracket the measured number.
By their numbers in this assay, from the lowest: compounds 2 and 1 (each within the scatter of the next); then compounds 4 and 3 (each within the scatter of the next).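

In this assay, the group entering at this saturated ring carbon does not bring the number back to the level of the methoxy-bearing aryl groups: the change is a 1.1-fold lower number from compound 3 to compound 4 (0.02 log units; within the scatter), against a 2.3-fold higher number from compound 2 to compound 4 (0.36 log units; beyond the scatter) and a 2.0-fold higher number from compound 1 to compound 4 (0.31 log units; beyond the scatter). Two different groups, 4-(methylsulfonyl)phenyl and the entering group, thus sit level, with 3,4-dimethoxyphenyl and 3,4,5-trimethoxyphenyl giving the lower numbers. Nothing measured here accounts for this result. Going by these compounds, it remains open where an unsubstituted phenyl, or an aryl group carrying an amine or a carboxylic acid, would fall at this carbon.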